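Swapping the Nitrophenyl Amide for a Furan

The compounds below may be only part of what the source reports. "The series", "measured", "known", "first", "only" and "open" are said of these compounds alone.

Compound 2 `O=C(Nc1nc(-c2ccccc2)nc2c1nnn2Cc1ccccc1)c1cccc([N+](=O)[O-])c1` in an assay (strain Wistar) for displacement of a labelled ligand from adenosine receptor A1 (Rattus norvegicus), read by scintillation counting (a lower number here means a stronger inhibitor, a higher number a weaker inhibitor), gives 77 nM, the second highest of the three numbers measured. Compound 3 `Nc1ccc(C(=O)Nc2nc(-c3ccccc3)nc3c2nnn3Cc2ccccc2)cc1` gives 7.1 nM, and compound 1 `COc1ccc(Cl)cc1C(=O)Nc1nc(-c2ccccc2)nc2c1nnn2Cc1ccccc1` gives 7150 nM. Compound 4 `O=C(Nc1nc(-c2ccccc2)nc2c1nnn2Cc1ccccc1)c1ccoc1` carries furan-3-yl in place of 3-nitrophenyl on a carbonyl carbon. Every measured step alters this same group on the carbonyl carbon: a 93-fold lower number from compound 1 to compound 2 (1.97 log units; beyond the scatter), an 11-fold lower number from compound 2 to compound 3 (1.04 log units; beyond the scatter) and a 1000-fold lower number from compound 1 to compound 3 (3.00 log units; beyond the scatter). From the compounds shown here alone, those steps show that this position can shift the number strongly in either direction, yet no furan has been measured, so the direction for compound 4 remains open. The expected step is a 1.9-fold higher number from compound 2 to compound 4 (0.29 log units; within the scatter), within the usual scatter. Compound 4 is therefore estimated at 150 nM, with a range from 30 nM to 800 nM.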

Compound 4, inhibition constant: 10 nM
Beside the measured number, compound 4's estimate is 15-fold (1.18 log units) above it; the measured number lies below the stated range.
By their numbers in this assay, from the lowest: compounds 3 and 4 (each within the scatter of the next); then compound 2; then compound 1.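

Going to furan-3-yl brings a 7.7-fold lower number from compound 2 to compound 4 (0.89 log units; beyond the scatter) and a 720-fold lower number from compound 1 to compound 4 (2.85 log units; beyond the scatter) and so shows that a low number at this position does not require a six-membered aromatic ring of carbon only. Then a 1.4-fold higher number from compound 3 to compound 4 (0.15 log units; within the scatter) stays within the usual scatter, so furan-3-yl and 4-aminophenyl cannot be ranked. No measurement at hand explains these steps.

From the compounds shown here alone, whether the ring oxygen or its point of attachment matters stays open. Furan-2-yl, thiophen-3-yl or a saturated cyclohexyl group on the same carbonyl carbon would address that.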